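Trifluoromethyl in Place of Chloro: What to Expect

The compounds below may be only part of what the source reports. "The series", "measured", "known", "first", "only" and "open" are said of these compounds alone.

Measured compounds:
Compound 1 `CN(C)C(=O)c1cc2cnc(Nc3ccc(NC(=O)C4(C(=O)Nc5ccc(Cl)cc5)CC4)cc3)nc2n1C1CCCC1`: 22.8%
Compound 2 `CN(C)C(=O)c1cc2cnc(Nc3ccc(NC(=O)C4(C(=O)Nc5cccc(Br)c5)CC4)cc3)nc2n1C1CCCC1`: 29.1%

Compound 1 and compound 2 share one core and differ only in the halogenated ring on the amide-type nitrogen. In a functional assay on T47D cells (Homo sapiens) for inhibition, read by CCK-8 assay, with a stated time of 72 h, tested at 1 uM (on this read-out lower numbers stand for less inhibition of growth and higher numbers for more inhibition of growth at the one concentration tested), compound 1 gives 22.8%, and compound 2 gives 29.1%. On paper compound 1 has the lower of the two numbers, but a number 6.3 percentage points higher from compound 1 to compound 2 (within the scatter), so the two cannot be separated by this read-out.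

Compound 3 `CN(C)C(=O)c1cc2cnc(Nc3ccc(NC(=O)C4(C(=O)Nc5ccc(C(F)(F)F)cc5)CC4)cc3)nc2n1C1CCCC1` is not yet measured. It differs from compound 1 in one place: trifluoromethyl in place of chloro on an aromatic carbon. Among the measured compounds shown here, the single measured step, 3-bromophenyl in place of 4-chlorophenyl, alters the same ring but not at the same place and not with the same group, so it bears on this change only loosely; its size was small and within the scatter. With nothing pointing either way, the step of a number 2.2 percentage points higher from compound 1 to compound 3 (within the scatter) is expected to stay within the scatter. Compound 3 is therefore estimated at 25%, with a range from 10% to 42%.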

Compound 3, percent growth inhibition at one concentration: 29.6%
Compound 3: the middle estimate sits 4.6 percentage points below what was measured; low and high end bracket the measured number.
By their numbers in this assay, from the lowest: compounds 1, 2 and 3 (each within the scatter of the next).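

In this assay, the swap at this ring carbon, para to a large group, puts four heavy atoms where one stood and still reads as a number 6.8 percentage points higher from compound 1 to compound 3 (within the scatter), so a chloro and a bulkier trifluoromethyl cannot be told apart here. The comparison with the other ring of the set reads as a number 0.5 percentage points higher from compound 2 to compound 3 (within the scatter), which means that 4-chlorophenyl, 3-bromophenyl and 4-(trifluoromethyl)phenyl now form a group of three whose numbers cannot be put in order by this read-out. No outside evidence bears on this result, so nothing shown can say why the number holds so steady across these changes.

Going by these compounds, all three rings carry a halogen or a fluorine-bearing group, so it remains open whether an amine, a carboxylic acid or a plain hydrogen on this carbon would move the number beyond the scatter. On these data alone, it also remains open whether these three compounds, which cannot be separated at the one concentration tested, would stay together at other concentrations.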